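A Larger Aromatic Group Replaces Carboxymethylamino in Compound 1

The source may report more compounds than this note shows. Statements on the series, on what has been measured and on what is new or still open speak of the compounds shown alone.

compound 1, `N#CC1=C(NCC(=O)O)N(c2ccccc2)C(=O)N2CCCCC(N3CCCC3)C12`: 67.2%
compound 2, `COc1ccc(N/C=N/C2=C(C#N)C3C(N4CCCC4)CCCCN3C(=O)N2c2ccccc2)cc1`: 20.6%
compound 3, `N#CC1=C(NCN2CCCCC2)N(c2ccccc2)C(=O)N2CCCCC(N3CCCC3)C12`: 29.7%

These three compounds share one core and were tested in a functional assay on the whole organism (strain albino) for inhibition, with Rattus norvegicus as the target, read by paw edema, with a stated time of 1 h, at a dose of 20 mmol/kg by the intraperitoneal route; a lower number here means less inhibition, a higher number more inhibition at the dose given (going by the name of the read-out). Compound 1 stands highest of the three; compound 3 lies nearer to it and compound 2 furthest, and both gaps are beyond the scatter. Compound 4, `N#CC1=C(/N=C/c2ccc([N+](=O)[O-])cc2)N(c2ccccc2)C(=O)N2CCCCC(N3CCCC3)C12`, is not yet measured. It differs from compound 1 in this way: a group of 11 heavy atoms (7 carbon, 2 nitrogen, 2 oxygen; one six-membered aromatic ring of carbon only) in place of a group of 5 heavy atoms (2 carbon, 1 nitrogen, 2 oxygen; no ring), on a double-bonded ring carbon.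

For the measured compounds named here, two measured steps bear on such a change. In a number 46.6 percentage points lower from compound 1 to compound 2 (beyond the scatter) a group containing an aromatic ring took the place of the carboxymethylamino group on a double-bonded ring carbon, and the inhibition fell sharply. In a number 37.5 percentage points lower from compound 1 to compound 3 (beyond the scatter) only the carboxy group was exchanged for piperidin-1-yl, and the inhibition again dropped well beyond the scatter. Every measured alteration of the carboxymethylamino group lowered the read-out, and none kept it high. Compound 4 also brings in a group with an aromatic ring in place of the carboxymethylamino group, so a large drop is expected, a number 42.2 percentage points lower from compound 1 to compound 4 (beyond the scatter). For compound 4 the estimated inhibition is 25%, expected to fall between 8% and 45%.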

Compound 4, a percentage reported as inhibition, in the whole organism at one dose (the size of the read-out at that dose, not a potency): 66%
Estimate against measurement, compound 4: 41 percentage points below, and the stated range ends below it.
By their numbers in this assay, from the lowest: compounds 2 and 3 (each within the scatter of the next); then compounds 4 and 1 (each within the scatter of the next).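

In this assay, the (carboxymethyl)amino group turns out not to be required for a high number on this double-bonded ring carbon: with a group that has an aromatic ring and no hydrogen-bond donors in its place, the step is a number 1.2 percentage points lower from compound 1 to compound 4 (within the scatter), and the earlier compounds had shown only losses at this position. An aromatic ring in the group therefore does not by itself bring the number down, and what surrounds that ring counts: 4-nitrophenyl in place of (4-methoxyphenyl)amino on a carbon with a double bond to nitrogen gives a number 45.4 percentage points higher from compound 2 to compound 4 (beyond the scatter), and the piperidin-1-yl-bearing group of compound 3 compares as a number 36.3 percentage points higher from compound 3 to compound 4 (beyond the scatter). Nothing shown here accounts for why these groups part so widely.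

From the compounds shown here alone, whether the nitro group matters remains open, and a plain phenyl or a 4-aminophenyl on the same carbon with a double bond to nitrogen would test it. A longer chain ending in a carboxylic acid would show how far the high number reaches on the side of compound 1.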